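This account rests on a few compounds, and the source may have more. Where it says the series, first, only, none or still open, it means among the compounds named here.

In a functional assay on ileum for inhibition of histamine H1 receptor (Cavia porcellus) (on this read-out lower numbers stand for stronger inhibition and higher numbers for weaker inhibition), compound 1 `CCCOCCn1c(N2CCN(C)CC2)nc2ccccc21` gives 20 nM and compound 2 `C#CCOCCn1c(N2CCN(C)CC2)nc2ccccc21` gives 12 nM; the change between them, a 1.7-fold lower number from compound 1 to compound 2 (0.22 log units; within the scatter), lies within the scatter. Compound 3 `COCCCn1c(N2CCN(C)CC2)nc2ccccc21` gives 860 nM, the highest number of the three, reached through a 43-fold higher number from compound 1 to compound 3 (1.63 log units; beyond the scatter) and a 72-fold higher number from compound 2 to compound 3 (1.86 log units; beyond the scatter). Compound 4 `CN1CCN(c2nc3ccccc3n2CCO)CC1` differs from compound 3 by hydroxy in place of methoxymethyl on a saturated chain carbon, two bonds along the chain from an aromatic nitrogen. Going by the values given here, no measured step alters this part of the chain in the same way; the two large steps that do bear on it, those leading to compound 3, both replaced a longer ether chain with a shorter one and weakened inhibition. A further shortening is therefore expected to keep the number high or raise it, and compound 4 is estimated at 2500 nM with a range from 400 nM to 15000 nM, a step of a 2.9-fold higher number from compound 3 to compound 4 (0.46 log units; beyond the scatter).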

Compound 4, half-maximal inhibitory concentration: 410 nM
Estimate against measurement, compound 4: 6.1-fold (0.79 log units) above; the range from low to high includes it.
By their numbers in this assay, from the lowest: compounds 2 and 1 (each within the scatter of the next); then compound 4; then compound 3.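

In this assay shortening the chain further does not keep weakening inhibition, since hydroxy in place of methoxymethyl gives a 2.1-fold lower number from compound 3 to compound 4 (0.32 log units; beyond the scatter) and so a modest recovery. The free hydroxy still falls far short of the longer ethers, with a 21-fold higher number from compound 1 to compound 4 (1.31 log units; beyond the scatter) and a 34-fold higher number from compound 2 to compound 4 (1.53 log units; beyond the scatter) on losing propyl or propargyl from the oxygen. No evidence here accounts for these shifts.

Going by these compounds, compound 4 changes chain length and the group on the oxygen at once, so which change gives the recovery stays open. A 2-methoxyethyl chain would separate the two, and an amine at the chain end would show whether the oxygen can be replaced.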